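The source may report more compounds than this note shows. Statements on the series, on what has been measured and on what is new or still open speak of the compounds shown alone.

Three compounds share one core and a long saturated chain joined to it through an amide; they differ only in the group on the other carbonyl carbon. Compound 1 `CCCCCCCCCCCCCCNC(=O)[C@@H](NC(=O)c1cccs1)[C@@H](C)O` carries a thiophen-2-yl group there, and in a functional assay on MCF7 cells (Homo sapiens) for cytotoxicity, read by MTT assay, with a stated time of 48 h (on this read-out lower numbers stand for stronger inhibition and higher numbers for weaker inhibition), compound 1 gives 36100 nM. Compound 2 `CCCCCCCCCCCCCCNC(=O)[C@@H](NC(=O)c1cc2ccccc2n1C)[C@@H](C)O` carries a 1-methyl-1H-indol-2-yl group instead, and in this assay compound 2 gives 25700 nM. Compound 3 `C/C=C/C=C/C(=O)N[C@H](C(=O)NCCCCCCCCCCCCCC)[C@@H](C)O` carries a penta-1,3-dien-1-yl group, and in this assay compound 3 gives 27800 nM. The steps among them, a 1.4-fold lower number from compound 1 to compound 2 (0.15 log units; within the scatter), a 1.3-fold lower number from compound 1 to compound 3 (0.11 log units; within the scatter) and a 1.1-fold higher number from compound 2 to compound 3 (0.03 log units; within the scatter), all fall within the scatter, so compound 3 holds the second highest of three numbers that cannot truly be told apart.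

Compound 4 `C/C=C/C=C/C(=O)N[C@H](C(=O)NCCCCCCCCCCCCCCCCCC)[C@@H](C)O` keeps the group of compound 3 and alters the chain: butyl in place of hydrogen on a saturated chain carbon, ten or more bonds along the chain from an amide-type nitrogen. For the measured compounds named here, no measured step touches the chain; every one of them swaps the group on the carbonyl carbon, and none moves the number beyond the scatter. The measured numbers therefore give no direction for this change, and the step expected in this assay is a 1.0-fold higher number from compound 3 to compound 4 (0.00 log units; within the scatter), nothing beyond the scatter. Compound 4 is estimated to give 28000 nM in this assay, with a range from 9000 nM to 80000 nM.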

Compound 4, half-maximal inhibitory concentration: 79600 nM
Estimate against measurement, compound 4: 2.8-fold (0.45 log units) below; the range from low to high includes it.
By their numbers in this assay, from the lowest: compounds 2, 3 and 1 (each within the scatter of the next); then compound 4.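

In this assay, butyl in place of hydrogen on a saturated chain carbon, ten or more bonds along the chain from an amide-type nitrogen, gives a 2.9-fold higher number from compound 3 to compound 4 (0.46 log units; beyond the scatter). For the compounds shown here, this modest step is the first in the set to pass beyond the scatter, and it points toward weaker inhibition, so extending the long saturated chain registers on this read-out, whereas the swaps on the carbonyl carbon among compound 1, compound 2 and compound 3 all stayed within the scatter. Nothing measured here accounts for the rise, so the result stands as an observation about one pair of compounds, with no established cause.

On these data alone, a single step cannot show whether the number changes steadily with chain length, so it remains open whether a shorter chain would lower the number or a still longer chain would raise it further. Also open, as far as these compounds go, are whether the same extension would have a similar effect alongside thiophen-2-yl or 1-methyl-1H-indol-2-yl in place of the group of compound 3, and how a chain ending in an amine or a carboxylic acid would behave.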